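Methyl added to the pyridine of a piperidine thiosemicarbazone

A few compounds are considered here, and "the series" means these few. Any claim that something is new, unique, unknown or untested is made for them only; others in the source may bear on it.

Measured so far:
compound 1 `Cc1ccnc(/C(N)=N/NC(=S)N2CCOCC2)c1`, 87.4%
compound 2 `Cc1ccnc(/C(N)=N/NC(=S)N2CCSCC2)c1`, 84.9%
compound 3 `N/C(=N\NC(=S)N1CCCCC1)c1ccccn1`, 87%

In a functional assay on A-375 cells (Homo sapiens) for cytotoxicity, read by MTT assay, with a stated time of 72 h, tested at 30 uM (a higher number here means more inhibition of growth at the concentration tested, a lower number less inhibition of growth), compound 3 gives 87%, and the three measured values all lie within the scatter of one another. Compound 4 `Cc1ccnc(/C(N)=N/NC(=S)N2CCCCC2)c1` differs from compound 3 by methyl in place of hydrogen on an aromatic carbon. Among the compounds with values here, no measured step follows this change directly; the only measured step, a number 2.5 percentage points lower from compound 1 to compound 2 (within the scatter), concerns the ring on the thiocarbonyl carbon and stays within the scatter. Compound 1, which already carries the methyl, shows a value much like compound 3. The step of no change at the digits printed from compound 3 to compound 4 (within the scatter) is therefore expected to stay within the scatter. Compound 4 is estimated at 87%, between 78% and 94%.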

Compound 4, percent growth inhibition at one concentration: 80%
The estimate for compound 4 lay 7 percentage points above the measured number, and the stated range covers the measured number.
By their numbers in this assay, from the lowest: compounds 4, 2, 3 and 1 (each within the scatter of the next).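

In this assay, within the data shown here, methyl in place of hydrogen on the aromatic carbon opposite the ring nitrogen gives a number 7 percentage points lower from compound 3 to compound 4 (within the scatter), so this is the first direct reading of the change at this position, and it stays within the scatter. With the methyl present throughout, changing the ring on the thiocarbonyl carbon gives a number 4.9 percentage points lower from compound 2 to compound 4 (within the scatter) and a number 7.4 percentage points lower from compound 1 to compound 4 (within the scatter), so the three rings are not told apart here. Nothing available explains these values.

From the compounds shown here alone, whether an amine, a carboxylic acid or a longer chain at this position would stay within the scatter remains open. A reading at one concentration also leaves open any difference in potency among these compounds.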